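Acetamido in place of ethoxy: what to expect of compound 4

The compounds below may be only part of what the source reports. "The series", "measured", "known", "first", "only" and "open" are said of these compounds alone.

In a functional assay on HepG2 cells (Homo sapiens) for antiproliferative activity, read by MTT assay, with a stated time of 48 h (on this read-out lower numbers stand for stronger inhibition and higher numbers for weaker inhibition), compound 3 (`CCOc1ccc(Nc2c(-c3ccc(OC)cc3)c(=O)oc3cc(OC)ccc23)cc1`) gives 31200 nM. Compound 2 (`COc1ccc(-c2c(Nc3ccc(C)c(O)c3)c3ccc(OC)cc3oc2=O)cc1`) gives 22500 nM, and compound 1 (`COc1ccc(-c2c(Nc3ccc(C)cc3)c3ccccc3oc2=O)cc1`) gives 59400 nM. The number of compound 3 lies within the scatter of both of these values.

Compound 4 (`COc1ccc(-c2c(Nc3ccc(NC(C)=O)cc3)c3ccc(OC)cc3oc2=O)cc1`) has not yet been measured. It differs from compound 3 in one place, acetamido in place of ethoxy on an aromatic carbon, para to a large group, so that 4-ethoxyphenyl becomes 4-acetamidophenyl.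

Going by the values given here, only one measured step bears on this change, as it alters the same group on nitrogen: a 1.4-fold higher number from compound 2 to compound 3 (0.14 log units; within the scatter), with 4-ethoxyphenyl in place of 3-hydroxy-4-methylphenyl. Among the compounds with values here, this is a single step, and no measured compound carries acetamido, so the guidance is thin.

Compound 4 is therefore expected to show no change beyond the scatter, an estimated 1.1-fold lower number from compound 3 to compound 4 (0.03 log units; within the scatter). For compound 4 the estimated value in this assay is 29000 nM, with an expected range from 12000 nM to 70000 nM.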

Compound 4, half-maximal inhibitory concentration: > 100000 nM
Compound 4 ended at the assay's limit; the forecaster's own chance of this, stated with the estimate: 8%; middle value at least 3.4-fold (0.53 log units) away from the limit.
By their numbers in this assay, from the lowest: compounds 2, 3 and 1 (each within the scatter of the next, the first and the last beyond it). At a limit, above all of these: compound 4.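

In this assay compound 4 gives > 100000 nM, which is a limit of the assay and not a number: the limit of > 100000 nM in this assay, at which 1 of the 4 values shown sits.

At this place, para to a large group, acetamido in place of ethoxy gives an at least 3.2-fold higher number from compound 3 to compound 4 (0.50 log units; beyond the scatter), whereas the earlier change of group on nitrogen stayed within the scatter, with a 1.4-fold higher number from compound 2 to compound 3 (0.14 log units; within the scatter). Setting 4-acetamidophenyl in place of 3-hydroxy-4-methylphenyl likewise gives an at least 4.4-fold higher number from compound 2 to compound 4 (0.64 log units; beyond the scatter), so this position does respond to the group it carries, and the response to acetamido is towards weaker inhibition.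

Going by these compounds, how far compound 4 lies past its limit remains open. Also open, on these data alone, is whether the weakening goes with the acetamido group as a whole or with the amide hydrogen, which a free amine or an N-methylacetamido group at the same place could begin to separate.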